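Thiosemicarbazones: nitro for chloro on the aryl ring

This account rests on a few compounds, and the source may have more. Where it says the series, first, only, none or still open, it means among the compounds named here.

Compound 1 `CC1=CC[C@H](C(C)(C)NC(=S)N/N=C/c2ccccc2)CC1` — 53900 nM
Compound 2 `CC1=CC[C@H](C(C)(C)NC(=S)N/N=C/c2ccccc2O)CC1` — 8400 nM
Compound 3 `CC1=CC[C@H](C(C)(C)NC(=S)N/N=C/c2ccccc2Cl)CC1` — 81000 nM

In a functional assay on NCI-H460 cells (Homo sapiens) for inhibition, read by sulforhodamine B assay, with a stated time of 48 h (on this read-out higher numbers stand for weaker inhibition of growth and lower numbers for stronger inhibition of growth), compound 3 gives the highest of the three numbers. Its nearest neighbour is compound 1, with a 1.5-fold higher number from compound 1 to compound 3 (0.18 log units; within the scatter); its furthest is compound 2, with a 9.6-fold higher number from compound 2 to compound 3 (0.98 log units; beyond the scatter). The hydroxy-bearing compound 2 thus sits apart from the other two, which lie within the scatter of each other.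

Compound 4 `CC1=CC[C@H](C(C)(C)NC(=S)N/N=C/c2ccccc2[N+](=O)[O-])CC1` carries nitro in place of chloro on an aromatic carbon, placed on an aromatic carbon of the six-membered carbon ring, ortho to a large group. Among the compounds with values here, no measured step swaps chloro for nitro. Within the data shown here, the steps that bear on it show that replacing hydrogen by chloro changed little, a 1.5-fold higher number from compound 1 to compound 3 (0.18 log units; within the scatter), while hydroxy gave a clearly lower number than chloro, a 9.6-fold higher number from compound 2 to compound 3 (0.98 log units; beyond the scatter). Nitro brings acceptors but no donor, so the number is expected to stay near that of compound 3, with at most a small downward move, a 1.6-fold lower number from compound 3 to compound 4 (0.21 log units; within the scatter). For compound 4 the estimate is 50000 nM, expected between 15000 nM and 150000 nM.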

Compound 4, concentration for total growth inhibition: 32700 nM
Estimate against measurement, compound 4: 1.5-fold (0.18 log units) above; the range from low to high includes it.
By their numbers in this assay, from the lowest: compound 2; then compounds 4, 1 and 3 (each within the scatter of the next, the first and the last beyond it).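

Swapping chloro for nitro at this position gives the first step beyond the scatter between two groups other than hydroxy, a 2.5-fold lower number from compound 3 to compound 4 (0.39 log units; beyond the scatter), so the position is not wholly indifferent to such replacements. Even so, the parent stays close to both groups: nitro in place of hydrogen gives a 1.6-fold lower number from compound 1 to compound 4 (0.22 log units; within the scatter), as small a change as chloro gave, and hydrogen therefore cannot be ranked against either group. Nitro also falls short of hydroxy, a 3.9-fold higher number from compound 2 to compound 4 (0.59 log units; beyond the scatter), leaving compound 2 with the lowest number of the four, and nothing on hand explains the differences among these groups.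

The compounds shown leave open whether the lower number of compound 2 is unique to hydroxy or would also appear with an amine or a methoxy group at the same place. They also leave open whether the small gap between compound 3 and compound 4 would hold up in a cell line other than NCI-H460.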